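Swapping a phenyl for a carbonyl-linked ring

The source may report more compounds than this note shows. Statements on the series, on what has been measured and on what is new or still open speak of the compounds shown alone.

Compound 1, `Cc1cc(C)c(S(=O)(=O)N2CCC(c3ccccc3)CC2)c(C)c1`, was tested in a functional assay on DLD-1 cells (Homo sapiens) for antiproliferative activity, read by CellTiter-Glo, with a stated time of 72 h; on this read-out higher numbers stand for weaker inhibition and lower numbers for stronger inhibition. In this assay compound 1 reaches only the limit of the assay, > 5000 nM, which is a boundary rather than a number (the limit of > 5000 nM in this assay, at which 1 of the 2 values shown sits). A second measured compound, compound 2, `COc1ccc(NC(=O)N2CCC(N3CCC(C)CC3)CC2)cc1`, gives 1360 nM in this assay; since it shares no single-point change with compound 1, the two values can only be set side by side.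

Compound 3, `Cc1cc(C)c(S(=O)(=O)N2CCC(C(=O)N3CCC(C)CC3)CC2)c(C)c1`, has not yet been measured. It differs from compound 1 in one place: (4-methylpiperidin-1-yl)carbonyl in place of phenyl on a saturated ring carbon. For the measured compounds named here, no step between measured compounds is known here, so the size of the step from compound 1 to compound 3 can only be guessed. With compound 1 sitting at a limit, the expectation for compound 3 is a step of a number no higher from compound 1 to compound 3 (the limit leaves the size open), most likely no larger than the usual scatter. Compound 3 is therefore estimated at 5000 nM, with a range from 1200 nM to 20000 nM.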

Compound 3, half-maximal inhibitory concentration: > 5000 nM
Compound 3 ended at the assay's limit; the forecaster's own chance of this, stated with the estimate: 50%; the middle value lies on the limit itself.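

No step can be read between compound 1 and compound 3, as both give a limit of the assay rather than a number: the limit of > 5000 nM in this assay, at which 2 of the 3 values shown sit. On these data alone, whether putting (4-methylpiperidin-1-yl)carbonyl in place of phenyl changes the activity of the shared core at all stays open.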